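A Four-Membered Ring Gives Way to a Cyanomethyl Group

The compounds below may be only part of what the source reports. "The series", "measured", "known", "first", "only" and "open" are said of these compounds alone.

Compound 1 `CC1(C(=O)NCCSc2nonc2/C(=N/O)Nc2ccc(F)c(C(F)F)c2)CCN1` is one of two compounds examined in an ADME assay on isolated protein for pharmacokinetics, with UDP-glucuronosyltransferase 1A9 (Homo sapiens) as the target, read by LC-MS, with a stated time of 60 min, at 37 degrees C, tested at 1 uM, in the presence of a further agent that is not named here; a higher number here means that the compound lasts longer, a lower number that the compound disappears faster. In this assay compound 1 gives > 3 h, which is a limit of the assay rather than a number. Compound 2 `N#Cc1cccc(N/C(=N\O)c2nonc2SCCNC(=O)CS(N)(=O)=O)c1` is the other member of the pair. In this assay compound 2 gives > 3 h, again a limit and not a number. Both results rest at the same boundary (the limit of > 3 h in this assay, at which 2 of the 2 values shown sit), so the numbers shown do not separate compound 1 from compound 2.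

Compound 3 `N#CCC(=O)NCCSc1nonc1/C(=N/O)Nc1ccc(F)c(C(F)F)c1` has not yet been measured in this assay. It differs from compound 1 by a group of 3 heavy atoms (2 carbon, 1 nitrogen; no ring) in place of a group of 5 heavy atoms (4 carbon, 1 nitrogen; one four-membered non-aromatic ring with 1 hetero atom), on a carbonyl carbon. Among the measured compounds shown here, no measured pair in this set differs in a single place, so the size of such a step is not known from data; the expectation is a change within the usual scatter, with no clear direction. The estimate for compound 3 in this assay is 3 h, ranging from 1.5 h to 6 h. This is expected to amount to a step of a number no higher from compound 1 to compound 3 (the limit leaves the size open).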

Compound 3, half-life: 1.73 h
Estimate against measurement, compound 3: 1.7-fold (0.24 log units) above, within the range that was stated.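

With the cyanomethyl group on the carbonyl carbon, compound 3 gives 1.73 h in this assay, the only result in this set that is a number rather than a limit, so this position now has a reading that can be placed on the scale. Replacing the group with the four-membered ring by cyanomethyl amounts to an at least 1.7-fold lower number from compound 1 to compound 3 (0.23 log units; that floor lies within the scatter), which means that the change may be small or may be much larger. Only a floor can be given for this step, and its true size stays unknown because the starting point is a limit and not a number: the limit of > 3 h in this assay, at which 2 of the 3 values shown sit.

The compounds shown leave open how far compound 1 lies beyond its limit, and so whether replacing its ring group has any real effect on the half-life. They also leave open how a plain methyl group, a primary amine or a carboxylic acid on the same carbonyl carbon would read, and whether cyanomethyl would give a similar result on the rest of compound 2.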